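The source may report more compounds than this note shows. Statements on the series, on what has been measured and on what is new or still open speak of the compounds shown alone.

Of the compounds shown here, three sharing one core have been measured in a functional assay (Platelet, plasma) for inhibition, with Homo sapiens as the target; on this read-out lower numbers stand for stronger inhibition and higher numbers for weaker inhibition. Compound 1 `N#Cc1cc2c(nc1N1CCC(C(=O)NS(=O)(=O)Cc3ccc(Cl)cc3)CC1)COC2=O` gives 4420 nM, compound 2 `Cc1ccc(CS(=O)(=O)NC(=O)C2CCN(c3nc4c(cc3C#N)C(=O)OC4)CC2)cc1` gives 4280 nM, and compound 3 `N#Cc1cc2c(nc1N1CCC(C(=O)NS(=O)(=O)c3ccc(Cl)s3)CC1)COC2=O` gives 4470 nM. The three numbers lie within the usual scatter of one another: the step from compound 1 to compound 2, methyl in place of chloro on an aromatic carbon, is a 1.0-fold lower number from compound 1 to compound 2 (0.01 log units; within the scatter); the step from compound 1 to compound 3, 5-chlorothiophen-2-yl in place of 4-chlorobenzyl on a sulfonyl sulfur, is a 1.0-fold higher number from compound 1 to compound 3 (0.00 log units; within the scatter); and the step from compound 2 to compound 3 is a 1.0-fold higher number from compound 2 to compound 3 (0.02 log units; within the scatter). Compound 3 thus stands with its two neighbours, none separable from the others.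

Compound 4 `CC1(C(=O)NS(=O)(=O)c2ccc(Cl)s2)CCN(c2nc3c(cc2C#N)C(=O)OC3)CC1` differs from compound 3 by methyl in place of hydrogen on a saturated ring carbon. For the measured compounds named here, none of the measured steps touches this place; all three exchange the group on the sulfonyl sulfur or the substituent on its aromatic ring, leaving the saturated ring untouched. Going by the values given here, no measured step therefore bears directly on this change. Among the compounds with values here, the only guidance is that the series so far has proved insensitive to its variations, so the step from compound 3 to compound 4 is expected to be a 1.0-fold higher number from compound 3 to compound 4 (0.00 log units; within the scatter), nothing beyond the scatter in either direction. Compound 4 is accordingly estimated at 4500 nM, with a range from 1500 nM to 13000 nM.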

Compound 4, half-maximal inhibitory concentration: 1640 nM
Compound 4: middle estimate off by 2.7-fold (0.44 log units), on the high side, within the range that was stated.
By their numbers in this assay, from the lowest: compound 4; then compounds 2, 1 and 3 (each within the scatter of the next).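

In this assay, for the compounds shown here, the exchange of hydrogen for methyl on a saturated ring carbon gives a 2.7-fold lower number from compound 3 to compound 4 (0.44 log units; beyond the scatter) and is the first step to lie beyond the scatter, though its size is modest. The earlier steps changed only the group on the sulfonyl sulfur or the substituent on its aromatic ring and stayed within the scatter, so this saturated ring carbon is the only place among those shown where a change has moved the number. Nothing available here accounts for the step.

As far as these compounds go, the methyl group has been seen on this ring carbon only with 5-chlorothiophen-2-yl on the sulfonyl sulfur, so it remains open whether the same step would appear with 4-chlorobenzyl or 4-methylbenzyl there. The compounds shown also leave open how far this position tolerates change, as they do not say whether an ethyl group, a fluorine atom or a hydroxyl group on the same carbon would lower the number further, leave it unchanged or raise it.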